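This account rests on a few compounds, and the source may have more. Where it says the series, first, only, none or still open, it means among the compounds named here.

Series to date:
`CC(=O)Nc1cccc(NC(=O)COc2ccc3c(=O)ccoc3c2)c1` compound 1, 136 nM
`O=C(COc1ccc2c(=O)ccoc2c1)Nc1cccc(NC(=O)c2ccc(Br)cc2)c1` compound 2, 49 nM
`Cc1cc(C(=O)Nc2cccc(NC(=O)COc3ccc4c(=O)ccoc4c3)c2)no1` compound 3, 5 nM

Compound 3 gives the lowest number of the three in an assay on isolated protein for inhibition of Rho-associated protein kinase 2 (Homo sapiens), read by scintillation counting, radiometric assay and 33P incorporation, with a stated time of 40 min, in the presence of a further agent that is not named here; a lower number here means a stronger inhibitor, a higher number a weaker inhibitor; the nearest measured neighbour is reached by a 9.8-fold lower number from compound 2 to compound 3 (0.99 log units; beyond the scatter), the furthest by a 27-fold lower number from compound 1 to compound 3 (1.43 log units; beyond the scatter).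

Compound 4 `Cn1ccc(S(=O)(=O)Nc2cccc(NC(=O)COc3ccc4c(=O)ccoc4c3)c2)n1` alters compound 3 by a group of 9 heavy atoms (4 carbon, 2 nitrogen, 2 oxygen, 1 sulfur; one five-membered aromatic ring with 2 hetero atoms) in place of a group of 8 heavy atoms (5 carbon, 1 nitrogen, 2 oxygen; one five-membered aromatic ring with 2 hetero atoms), on a nitrogen on an aromatic ring. For the measured compounds named here, no measured step covers this exchange. Going by the values given here, the steps of a 27-fold lower number from compound 1 to compound 3 (1.43 log units; beyond the scatter) and a 9.8-fold lower number from compound 2 to compound 3 (0.99 log units; beyond the scatter) show that the group leaving here accounts for the whole gain seen in this assay so far, and compound 4 gives that group up for one without precedent. Some loss is therefore expected. For compound 4 the expected step is a 12-fold higher number from compound 3 to compound 4 (1.08 log units; beyond the scatter). Compound 4 is expected at 60 nM (range 15 nM to 250 nM).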

Compound 4, half-maximal inhibitory concentration: 1350 nM
Compound 4: the middle estimate sits 23-fold (1.35 log units) below what was measured; the measured number lies above the stated range.
By their numbers in this assay, from the lowest: compound 3; then compound 2; then compound 1; then compound 4.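

In this assay the group on this nitrogen can cost activity as well as gain it, as the exchange in compound 4 shows (a 270-fold higher number from compound 3 to compound 4 (2.43 log units; beyond the scatter)). The sulfur-bearing group also falls behind the groups of compound 2 (a 28-fold higher number from compound 2 to compound 4 (1.44 log units; beyond the scatter)) and compound 1 (a 9.9-fold higher number from compound 1 to compound 4 (1.00 log units; beyond the scatter)), so a five-membered aromatic ring with 2 hetero atoms does not by itself carry the gain. No measurement shown accounts for this loss.

Going by these compounds, the ring and its link to the nitrogen change together, so their separate shares remain open. A sulfur-linked 5-methyl-1,2-oxazol-3-yl group would separate them.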